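Removing a side chain from the shared core

The source may hold more compounds than are shown below. What is called first, only, known or untested is meant among the compounds shown, and "the series" means these compounds.

Compound 1 `C[C@H]1N=C2C[C@H]3C[C@H](C3(C)C)[C@@]2(C)OC1=O`: 38000 nM
Compound 2 `CC1(C)[C@H]2CC3=N[C@H](CCC(=O)O)C(=O)O[C@]3(C)[C@@H]1C2`: 34000 nM

In a functional assay on MCF7 cells (Homo sapiens) for antiproliferative activity, read by sulforhodamine B assay, with a stated time of 48 h (on this read-out higher numbers stand for weaker inhibition and lower numbers for stronger inhibition), compound 1 gives 38000 nM and compound 2 gives 34000 nM. Compound 2 carries the lower of the two numbers, yet the step of a 1.1-fold lower number from compound 1 to compound 2 (0.05 log units; within the scatter) lies within the scatter, so the two compounds cannot be separated on this read-out. Compound 3 `CC1(C)[C@H]2CC3=NCC(=O)O[C@]3(C)[C@@H]1C2` has not been measured. It differs from compound 2 in one place: hydrogen in place of 2-carboxyethyl on a saturated ring carbon. Within the data shown here, the only measured step that touches this position, a 1.1-fold lower number from compound 1 to compound 2 (0.05 log units; within the scatter), added a chain here and left the number essentially unchanged. Removing that chain altogether is therefore expected to give no step beyond the scatter, and the change from compound 2 to compound 3 is estimated as a 1.2-fold higher number from compound 2 to compound 3 (0.07 log units; within the scatter). Compound 3 is expected to give 40000 nM in this assay, with a range of 15000 nM to 110000 nM.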

Compound 3, half-maximal inhibitory concentration: > 300000 nM
Compound 3: no number, only a limit; the forecaster's own chance of this, stated with the estimate: 15%; at least 7.5-fold (0.87 log units) between middle value and limit.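

Compound 3 has no exact number in this assay, only a limit: the limit of > 300000 nM in this assay, at which 1 of the 3 values shown sits.

Even so, the steps can be read: hydrogen in place of 2-carboxyethyl on this saturated ring carbon gives an at least 8.8-fold higher number from compound 2 to compound 3 (0.94 log units; beyond the scatter), and hydrogen in place of methyl at the same carbon gives an at least 7.8-fold higher number from compound 1 to compound 3 (0.89 log units; beyond the scatter). The earlier pair suggested that this position hardly mattered, but the new compound shows that having either group here gives a clearly lower number than bare hydrogen, even though the two groups themselves cannot be told apart.

Going by these compounds, what remains open is how much of the effect depends on the kind of group rather than on having any group at all. An ethyl group, or a longer chain ending in an amine, could help to separate those two possibilities.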